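A nitro group on the aryl ring of a piperidine ester

This account rests on a few compounds, and the source may have more. Where it says the series, first, only, none or still open, it means among the compounds named here.

Two compounds share a core in which a methyl ester and an aryl ring sit on a three-membered ring, linked through a piperidine that carries a benzyl group. Compound 1 `COC(=O)C1(c2ccc(C)cc2)CC1CN1CCC(Cc2ccccc2)CC1` gives 0.97 nM in an assay for displacement of a labelled ligand from Sigma non-opioid intracellular receptor 1 (Cavia porcellus); a higher number here means a weaker inhibitor, a lower number a stronger inhibitor. Its partner without the methyl group is compound 2 `COC(=O)C1(c2ccccc2)CC1CN1CCC(Cc2ccccc2)CC1`, and in this assay compound 2 gives 2.2 nM. For the measured compounds named here, the one step within the set, a 2.3-fold higher number from compound 1 to compound 2 (0.36 log units; beyond the scatter), is modest but beyond the scatter, and it leaves compound 2 with the higher of the two numbers.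

Compound 3 `COC(=O)C1(c2ccc([N+](=O)[O-])cc2)CC1CN1CCC(Cc2ccccc2)CC1` is the next variation: nitro in place of hydrogen on an aromatic carbon, on an aromatic carbon of a six-membered aromatic ring of carbon only, para to a large group. Going by the values given here, only the step from compound 1 to compound 2 touches this part of the molecule, and it concerns a different group, so it speaks to compound 3 only loosely. Compound 3 is therefore expected to land near compound 2, with a step of a 1.1-fold lower number from compound 2 to compound 3 (0.04 log units; within the scatter) that may well fall within the scatter. The estimate for compound 3 in this assay is 2 nM, within a range from 0.7 nM to 6 nM.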

Compound 3, inhibition constant: 0.68 nM
Beside the measured number, compound 3's estimate is 2.9-fold (0.47 log units) above it; measured number below the stated range.
By their numbers in this assay, from the lowest: compounds 3 and 1 (each within the scatter of the next); then compound 2.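

In this assay, placing a nitro group on this aromatic carbon, para to a large group, gives a modest change (a 3.2-fold lower number from compound 2 to compound 3 (0.51 log units; beyond the scatter)) that lies beyond the scatter, so this position accepts a group of three heavy atoms with no loss of binding. Exchanging methyl for nitro at the same carbon gives a step (a 1.4-fold lower number from compound 1 to compound 3 (0.15 log units; within the scatter)) that lies within the scatter, so compound 1 and compound 3 cannot be told apart in this measurement. For the compounds shown here, until now, methyl was the only group seen here; now two quite different groups both give a lower number than the hydrogen of compound 2, though two groups are too few to support a general rule.

The compounds shown leave open whether a chlorine atom, a methoxy group or an amine on this same carbon would follow compound 1 and compound 3 or break from them. They also leave open whether a nitro group on another carbon of this aromatic ring would do as well. Nothing presented here explains why either group gives a lower number than hydrogen.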